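Chloro to fluoro on a shared core: expected effect

The compounds below may be only part of what the source reports. "The series", "measured", "known", "first", "only" and "open" are said of these compounds alone.

Compound 1, `C=CC(=O)Nc1cccc(Nc2nc(Nc3ccc(OCCn4ccnc4)cc3)ncc2F)c1`: 40000 nM
Compound 2, `C=CC(=O)Nc1cccc(Nc2nc(Nc3ccc(Cn4ccnc4)cc3OC)ncc2Cl)c1`: > 40000 nM
Compound 3, `C=CC(=O)Nc1cccc(Nc2nc(Nc3ccc(Cn4ccnc4)cc3)ncc2Cl)c1`: > 40000 nM

Of the compounds shown here, three have been measured in an ADME assay on NHBE cells (Homo sapiens) for antiproliferative activity, read by MTT assay, with a stated time of 48 h; a lower number here means a stronger inhibitor, a higher number a weaker inhibitor. Compound 1 gives 40000 nM. For compound 2 the result > 40000 nM is a limit of the assay, not a number. For compound 3 the result > 40000 nM is likewise a limit. Within the data shown here, the only single-point comparison, a step that the two limits leave unreadable from compound 2 to compound 3, therefore cannot be read, because the limit of > 40000 nM in this assay, at which 2 of the 3 values shown sit, holds both ends of it. Compound 3 thus stands at the limit, together with one other value, while compound 1 sits at a number of the same magnitude.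

Compound 4, `C=CC(=O)Nc1cccc(Nc2nc(Nc3ccc(Cn4ccnc4)cc3)ncc2F)c1`, differs from compound 3 by fluoro in place of chloro on an aromatic carbon. Among the measured compounds shown here, compound 1 and compound 3 differ in two places, so their values show only that a fluoro-bearing core and a chloro-bearing core both landed at or near the ceiling. For the measured compounds named here, no measured step speaks directly to this change. The step from compound 3 to compound 4 is therefore expected to be a number no higher from compound 3 to compound 4 (the limit leaves the size open), nothing beyond the scatter. Compound 4 is expected to give about 40000 nM, between 20000 nM and 80000 nM.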

Compound 4, half-maximal inhibitory concentration: > 40000 nM
Compound 4 was reported as a limit; the forecaster's own chance of this, stated with the estimate: 70%; the middle value lies on the limit itself.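

In this assay compound 4 gives > 40000 nM as its result, and this is a limit of the assay, not a number. The chloro compound and the fluoro compound on this aromatic carbon now both stand at that limit, so the new information is only that fluoro in place of chloro leaves the result there. For (1H-imidazol-1-yl)methyl in place of 2-(1H-imidazol-1-yl)ethoxy the data give a number no lower from compound 1 to compound 4 (the limit leaves the size open). As far as these compounds go, the step for fluoro in place of chloro cannot be read, so the size of that change stays unknown, because both of its ends are tied to one ceiling: the limit of > 40000 nM in this assay, at which 3 of the 4 values shown sit.

The compounds shown leave open whether a hydrogen, a methyl or a nitrile on this same carbon would give a true number under the limit. They also leave open what an amine in place of the imidazole-bearing chain would do.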